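The source may hold more compounds than are shown below. What is called first, only, known or untested is meant among the compounds shown, and "the series" means these compounds.

Measured so far in a functional assay on BT-549 cells (Homo sapiens) for cytotoxicity, read by sulforhodamine B assay, with a stated time of 48 h; on this read-out lower numbers stand for higher toxicity in this test and higher numbers for lower toxicity in this test:
- compound 1 `ClCc1cccc(Cn2cnc3c(Cl)ncnc32)c1`: 60300 nM
- compound 2 `ClCc1cccc(Cn2cnc3c(Cl)nc(Cl)nc32)c1`: 6160 nM
- compound 3 `ClCc1ccccc1Cn1cnc2ncnc(Cl)c21`: 25100 nM

Compound 1 and compound 2 share a core and differ by one change, (chloro in place of hydrogen on an aromatic carbon). That change gave a 9.8-fold lower number from compound 1 to compound 2 (0.99 log units; beyond the scatter), a shift well beyond the usual scatter of this assay.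

Compound 3 carries a core built from the same atoms as compound 1, joined differently; the difference between the two cores is not broken down here. In this assay compound 3 gives 25100 nM, which sits below the number for compound 1 and above the number for compound 2.

Compound 4 `ClCc1ccccc1Cn1cnc2nc(Cl)nc(Cl)c21` is not yet measured. It stands to compound 3 as compound 2 stands to compound 1: the change is chloro in place of hydrogen on an aromatic carbon, and its surroundings as described are the same word for word as in the step from compound 1 to compound 2, so it is the same change on a related core. Going by the values given here, the only precedent for it is a 9.8-fold lower number from compound 1 to compound 2 (0.99 log units; beyond the scatter). On that basis a step of similar size is expected, a 9.7-fold lower number from compound 3 to compound 4 (0.98 log units; beyond the scatter), with the caveat that it rests on a single precedent and on a core whose relation to that of compound 1 is not broken down. Compound 4 is therefore estimated at 2600 nM, with a range from 1000 nM to 6500 nM.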

Compound 4, concentration lethal to 50% of the cells: 7070 nM
The estimate for compound 4 lay 2.7-fold (0.43 log units) below the measured number; the measured number lies above the stated range.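

Chloro in place of hydrogen on an aromatic carbon, here between two ring nitrogen atoms, again goes with a lower number in this assay, with a 3.6-fold lower number from compound 3 to compound 4 (0.55 log units; beyond the scatter). The direction of the step carries over to the second core, but its size does not: the same change on two cores in this assay, a 9.8-fold lower number (0.99 log units; beyond the scatter) from compound 1 to compound 2 and a 3.6-fold lower number (0.55 log units; beyond the scatter) from compound 3 to compound 4, 2.8-fold (0.44 log units) apart, beyond the scatter of two such steps

This shows that the change can be carried across these two cores as a matter of sign, while a step size taken from one core is not a safe figure for the other; it does not show which part of the difference between the cores goes with the smaller step, and two steps give no basis for a general rule or for a prediction on a third core.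

The compounds shown leave open whether another group on that same aromatic carbon, such as an amine, a methoxy group or a nitrile, would move the number in the same direction as chloro. They also leave open how much of the read-out depends on the chloromethyl group, which is present throughout and could be set against a methyl or hydroxymethyl group on each core.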